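A few compounds are considered here, and "the series" means these few. Any claim that something is new, unique, unknown or untested is made for them only; others in the source may bear on it.

Three related compounds have been tested in a functional assay on KETR3 cells (Homo sapiens) for inhibition, read by MTT assay, with a stated time of 120 h; on this read-out lower numbers stand for stronger inhibition and higher numbers for weaker inhibition. Compound 1 `CC(NC(=O)/C=C/c1ccc(NC(=O)Nc2ccc(Cl)c(C(F)(F)F)c2)cc1)c1ccccc1` gives a true number there, 21200 nM. Compound 2 `CC(NC(=O)CCc1ccc(NC(=O)Nc2ccc(Cl)c(C(F)(F)F)c2)cc1)c1ccccc1` gives no exact number, and its > 50000 nM is a limit of the assay. Compound 3 `C/C(=C\C(=O)NC(C)c1ccccc1)c1ccc(NC(=O)Nc2ccc(Cl)c(C(F)(F)F)c2)cc1` also gives a limit, > 50000 nM. As far as these compounds go, compound 2 therefore stands with compound 3 at the limit of > 50000 nM in this assay, at which 2 of the 3 values shown sit, and its real value is unknown.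

The next compound changes one end of compound 2. Compound 4 `CC1CN(C(=O)CCc2ccc(NC(=O)Nc3ccc(Cl)c(C(F)(F)F)c3)cc2)CC(C)O1` carries 2,6-dimethylmorpholin-4-yl in place of (1-phenylethyl)amino on a carbonyl carbon. The rest of the structure stays the same. No measured pair among these compounds shows what this exchange does, so the data offer no guide to a direction.

The expectation is therefore no step beyond the usual scatter in this assay, with compound 4 most likely staying at the limit as well. The estimated a number no higher from compound 2 to compound 4 (the limit leaves the size open) reflects that lack of any expected change. The estimate for compound 4 is 50000 nM, with an expected range from 20000 nM to 100000 nM.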

Compound 4, half-maximal inhibitory concentration: > 50000 nM
Compound 4: only a limit was reported (the forecaster's own chance of this, stated with the estimate: 75%); the middle value lies on the limit itself.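

Compound 2 and compound 4 both stop at a limit in this assay rather than at a number, so no step between them can be read: the limit of > 50000 nM in this assay, at which 3 of the 4 values shown sit.

The compounds shown leave open whether 2,6-dimethylmorpholin-4-yl in place of (1-phenylethyl)amino on a carbonyl carbon changes inhibition at all, and in which direction.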